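From a methoxycarbonylphenyl to a furan-2-yl group

A few compounds are considered here, and "the series" means these few. Any claim that something is new, unique, unknown or untested is made for them only; others in the source may bear on it.

Compound 2 `CCOC(=O)Nc1cc(NC(=O)c2ccccc2)c2[nH]c(-c3ccc(C(=O)OC)cc3)nc2c1` is the compound with the only numerical result here. In an ADME assay on Vero cells (Chlorocebus sabaeus) for cytotoxicity, with a stated time of 3 days (on this read-out higher numbers stand for weaker inhibition and lower numbers for stronger inhibition), compound 2 gives 650 ug/mL. Compound 1 `CCOC(=O)Nc1cc(NC(=O)C2CCCCC2)c2[nH]c(-c3ccc(C(=O)OC)cc3)nc2c1` differs from it by a cyclohexyl in place of the phenyl on a carbonyl carbon. In this assay compound 1 gives > 200 ug/mL, which is a limit of the assay rather than a number. The step that the limit leaves unreadable from compound 1 to compound 2 therefore cannot be sized, as the limit of > 200 ug/mL in this assay, at which 1 of the 2 values shown sits, shows. Compound 3 `CCOC(=O)Nc1cc(NC(=O)c2ccccc2)c2[nH]c(-c3ccco3)nc2c1` differs from compound 2 by furan-2-yl in place of 4-(methoxycarbonyl)phenyl on an aromatic carbon. For the measured compounds named here, no measured pair changes this part of the structure, so none of the measured steps bears on it, and the only measured step is itself unreadable. The expected step of a 1.4-fold lower number from compound 2 to compound 3 (0.16 log units; within the scatter) is therefore nothing beyond the usual scatter. For compound 3 in this assay the estimate is 450 ug/mL, expected to fall between 120 ug/mL and 1200 ug/mL.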

Compound 3, half-maximal inhibitory concentration: > 200 ug/mL
Compound 3 gave a limit, no number; the forecaster's own chance of this, stated with the estimate: 40%; the middle value does not contradict the limit.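

Compound 3 gives a limit of the assay rather than a number, so no new step can be read from compound 2 to compound 3: the limit of > 200 ug/mL in this assay, at which 2 of the 3 values shown sit.

The compounds shown leave open how large a change, if any, furan-2-yl in place of 4-(methoxycarbonyl)phenyl brings in this assay.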